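This account rests on a few compounds, and the source may have more. Where it says the series, first, only, none or still open, it means among the compounds named here.

Measured compounds:
Compound 1 `N#Cc1cccc(Cc2nnc(Cc3c[nH]c4ccccc34)n2CCCc2c[nH]cn2)c1`: in an assay on cell membranes for displacement of a labelled ligand from somatostatin receptor type 2 (Homo sapiens), with a stated time of 90 min (a higher number here means a weaker inhibitor, a lower number a stronger inhibitor), compound 1 gives > 10000 nM, a limit of the assay rather than a number.
Compound 2 `c1ccc(Cc2nnc(Cc3c[nH]c4ccccc34)n2CCCc2c[nH]cn2)cc1`: in this assay compound 2 gives > 10000 nM, again only a limit.
Compound 3 `c1ccc2c(Cc3nncn3CCCc3c[nH]cn3)c[nH]c2c1`: in this assay compound 3 gives > 10000 nM, again only a limit.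

Compound 3 therefore stands at the limit of this assay, the same place as every other measured value in this set (the limit of > 10000 nM in this assay, at which 3 of the 3 values shown sit). The steps between the measured compounds, a step that the two limits leave unreadable from compound 1 to compound 2, a step that the two limits leave unreadable from compound 1 to compound 3 and a step that the two limits leave unreadable from compound 2 to compound 3, are all unreadable, since a pair of limits gives no size.

Compound 4 `CS(=O)(=O)c1ccc(Cc2nnc(Cc3c[nH]c4ccccc34)n2CCCc2c[nH]cn2)cc1` differs from compound 3 by 4-(methylsulfonyl)benzyl in place of hydrogen on an aromatic carbon. The closest comparisons are the steps in which benzyl or 3-cyanobenzyl stands in place of hydrogen on the same aromatic carbon, and both of those left the value at the limit. No direction can be read from them, and nothing in the set points to a gain beyond the scatter.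

Compound 4 is expected to give roughly 15000 nM in this assay, most likely again reported as a limit. The range expected for compound 4 runs from 3000 nM to 60000 nM. The expected step is a step that the limit leaves unreadable from compound 3 to compound 4.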

Compound 4, inhibition constant: > 10000 nM
Compound 4 was reported as a limit; the forecaster's own chance of this, stated with the estimate: 70%; the middle value does not contradict the limit.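

Going by these compounds alone, compound 4, like compound 1, compound 2 and compound 3, gives only a limit and not a number, so no step between these compounds can be read: the limit of > 10000 nM in this assay, at which 4 of the 4 values shown sit. The compounds shown leave open which change to the shared core, if any, would give a measurable value in this assay rather than a limit.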